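This account rests on a few compounds, and the source may have more. Where it says the series, first, only, none or still open, it means among the compounds named here.

Measured compounds:
- compound 1, `COc1cc(-c2nn(-c3cccc(NC(=O)Nc4cc(C(F)(F)F)cc(C(F)(F)F)c4)c3)cc2-c2ccncc2)ccc1Cl`, 410 nM
- compound 2, `COc1cc(-c2nn(-c3cccc(NC(=O)Nc4ccc(Cl)c(Cl)c4)c3)cc2-c2ccncc2)ccc1Cl`, 700 nM

Both compounds were tested in a functional assay on OVCAR-3 cells (Homo sapiens) for inhibition, read by sulforhodamine B assay, with a stated time of 48 h; on this read-out lower numbers stand for stronger inhibition and higher numbers for weaker inhibition. Compound 1 gives 410 nM in this assay, and compound 2 gives 700 nM. Of the two numbers, compound 2 has the higher one, yet the gap between compound 2 and compound 1 lies within the scatter of repeated measurements, so the two cannot be told apart on this evidence.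

Compound 3, `COc1cc(-c2nn(-c3cccc(NC(=O)Nc4cccc(C(F)(F)F)c4)c3)cc2-c2ccncc2)ccc1Cl`, has not yet been measured in this assay. It differs from compound 2 in one place: 3-(trifluoromethyl)phenyl in place of 3,4-dichlorophenyl on an amide-type nitrogen. Among the compounds with values here, no step between measured compounds isolates this exchange, so there is no directly comparable precedent. The two measured compounds, which carry different substituted phenyl groups on the same amide-type nitrogen, sit within the scatter of one another, which suggests that this part of the molecule tolerates such exchanges without large shifts.

On that basis the step of a 1.1-fold higher number from compound 2 to compound 3 (0.06 log units; within the scatter) is expected to stay within the scatter, in no clear direction. Compound 3 is therefore estimated at 800 nM, with a range from 350 nM to 1900 nM.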

Compound 3, half-maximal inhibitory concentration: 580 nM
For compound 3 the middle estimate is 1.4-fold (0.14 log units) above the measured one, and the stated range covers the measured number.
By their numbers in this assay, from the lowest: compounds 1, 3 and 2 (each within the scatter of the next).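

In this assay the exchange of 3,4-dichlorophenyl for 3-(trifluoromethyl)phenyl on the amide-type nitrogen can now be read directly, as a 1.2-fold lower number from compound 2 to compound 3 (0.08 log units; within the scatter) and it lies within the scatter. The second step, a 1.4-fold higher number from compound 1 to compound 3 (0.15 log units; within the scatter) with hydrogen in place of trifluoromethyl on an aromatic carbon, also lies within the scatter, so taking away one of the two trifluoromethyl groups of compound 1 gives no change that this read-out can resolve. Both exchanges at this phenyl group therefore leave the compounds indistinguishable, and nothing available explains why this is so.

What the compounds shown leave open is whether this tolerance extends beyond phenyl groups carrying halogen or trifluoromethyl substituents, for instance to a phenyl group carrying an amine or a carboxylic acid, or to a longer alkyl chain on the amide-type nitrogen in place of the phenyl group. They also leave open how the shared core responds to changes of its own, since every step here falls within this one substituent.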